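The source may report more compounds than this note shows. Statements on the series, on what has been measured and on what is new or still open speak of the compounds shown alone.

Measured so far:
- compound 1 `COc1ccc(S(=O)(=O)N2CCc3cccc(-c4ccc(F)cc4)c32)cc1`: 94.6 nM
- compound 2 `COc1ccc(S(=O)(=O)N2CCc3cccc(-c4c(F)c(F)c(F)c(F)c4F)c32)cc1`: 4630 nM
- compound 3 `COc1ccc(S(=O)(=O)N2CCc3cccc(-c4cc(OC)c(OC)c(OC)c4)c32)cc1`: 4670 nM

The three measured compounds share the same sulfonamide core and differ only in the aryl group attached to it. In a functional assay on KB-VIN10 cells (Homo sapiens) for inhibition, with a stated time of 72 h (on this read-out lower numbers stand for stronger inhibition and higher numbers for weaker inhibition), compound 1 gives 94.6 nM, the lowest number of the three. Compound 2 sits far above it, and compound 3 likewise, both gaps well beyond the usual scatter, so compound 1 is the most potent of the measured set. Both weaker compounds carry a heavily substituted aryl group; compound 1 carries a single fluoro.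

The next compound, compound 4 `COc1ccc(S(=O)(=O)N2CCc3cccc(-c4ccc(N(C)C)cc4)c32)cc1`, keeps the single-substituent pattern but changes the substituent: dimethylamino in place of fluoro on an aromatic carbon. Cut one bond further out, this reads as 4-fluorophenyl to 4-(dimethylamino)phenyl, a change that adds heavy atoms and one hydrogen-bond acceptor while leaving the substitution pattern of the aryl ring otherwise untouched.

Among the measured compounds shown here, no measured pair shows this exact step, so the expectation rests on compound 1 alone. A modest loss is expected in this assay, smaller than the drop seen for compound 2 or compound 3, because the number for compound 1 at 94.6 nM comes from a singly substituted aryl ring that compound 4 retains. The step from compound 1 to compound 4 is estimated as a 2.6-fold higher number from compound 1 to compound 4 (0.42 log units; beyond the scatter). Compound 4 is expected to give 250 nM, within 50 nM to 2500 nM.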

Compound 4, half-maximal inhibitory concentration: 553 nM
Estimate against measurement, compound 4: 2.2-fold (0.34 log units) below; measured number inside the range.
By their numbers in this assay, from the lowest: compound 1; then compound 4; then compounds 2 and 3 (each within the scatter of the next).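

In this assay the series gains its first comparison that changes one place only, and dimethylamino in place of fluoro on this aromatic carbon gives a 5.8-fold higher number from compound 1 to compound 4 (0.77 log units; beyond the scatter) with the rest of compound 1 unchanged. The earlier compounds shown here differ from compound 1 in more than one place on the aryl ring, so they could not show that this single position alone responds to the group it carries, with fluoro the better of the two groups compared here. No measurement available here accounts for the size or direction of this step.

As far as these compounds go, it remains open whether this loss is tied to dimethylamino or would follow any replacement of fluoro, which hydrogen, chloro or methoxy at the same place could help separate. From the compounds shown here alone, how a primary amine or a carboxylic acid would fare there is also open.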